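From furan-2-yl to 2-phenylethenyl on the shared core

This account rests on a few compounds, and the source may have more. Where it says the series, first, only, none or still open, it means among the compounds named here.

Compound 1 `O=C1C(=Cc2ccc(Cl)cc2Cl)C(=O)N(c2ccc(Cl)cc2)N1c1ccc(Cl)cc1`: > 128000 nM
Compound 2 `O=C1C(=Cc2ccco2)C(=O)N(c2ccc(Cl)cc2)N1c1ccc(Cl)cc1`: 12800 nM

The entry for compound 1 is a limit, not a number. For the measured compounds named here, in a functional assay on MGC-803 cells (Homo sapiens) for cytotoxicity, read by MTT assay, with a stated time of 72 h (a higher number here means a weaker inhibitor, a lower number a stronger inhibitor), compound 2 gives 12800 nM, the only actual number so far. Compound 3 `O=C1C(=C/C=C/c2ccccc2)C(=O)N(c2ccc(Cl)cc2)N1c1ccc(Cl)cc1` carries 2-phenylethenyl in place of furan-2-yl on a double-bonded chain carbon bound to a double-bonded ring carbon. Going by the values given here, one measured step bears on this place, an at least 10-fold lower number from compound 1 to compound 2 (1.00 log units; beyond the scatter), and there furan-2-yl replaced a carbon-only aromatic group. Compound 3 gives up furan-2-yl again, so a modest move to a higher number in this assay is expected, though this rests on a single step. The estimated change is a 2.3-fold higher number from compound 2 to compound 3 (0.37 log units; beyond the scatter). For compound 3 the expected value is 30000 nM, with an estimated range of 7000 nM to 100000 nM.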

Compound 3, half-maximal inhibitory concentration: 5100 nM
Compound 3: middle estimate off by 5.9-fold (0.77 log units), on the high side, and the stated range ends above it.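

In this assay, a carbon-only aromatic ring at this place does not by itself go with a higher number: 2-phenylethenyl in place of furan-2-yl gives a 2.5-fold lower number from compound 2 to compound 3 (0.40 log units; beyond the scatter). Against 2,4-dichlorophenyl, the same group gives an at least 25-fold lower number from compound 1 to compound 3 (1.39 log units; beyond the scatter), so furan-2-yl is not needed for a gain over compound 1. That second step is only a bound, set by a single entry: the limit of > 128000 nM in this assay, at which 1 of the 3 values shown sits.

Compound 3 brings in both a chain double bond and a phenyl ring, and the compounds shown do not separate the two. From the compounds shown here alone, what a saturated 2-phenylethyl group or an amine on the phenyl ring would give remains open.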